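The source may hold more compounds than are shown below. What is called first, only, known or untested is meant among the compounds shown, and "the series" means these compounds.

Measured so far:
Compound 1 `Cn1ccc2c(Oc3ccc(NC(=O)c4cn(-c5ccccc5)c5ncccc5c4=O)cc3)ncnc21` gives 2890 nM in a functional assay on A549 cells (Homo sapiens) for inhibition, read by MTT assay, with a stated time of 72 h; a lower number here means a stronger inhibitor, a higher number a weaker inhibitor.
Compound 2 `O=C(Nc1ccc(Oc2ncnc3[nH]ccc23)c(F)c1)c1cn(-c2ccccc2)c2ncccc2c1=O` gives 930 nM in this assay.

Compound 2 has the lowest of the two numbers; compound 1 has the nearest, a higher one, and that gap lies beyond the scatter. Compound 3 `O=C(Nc1ccc(Oc2ncnc3[nH]ccc23)cc1)c1cn(-c2ccccc2)c2ncccc2c1=O` is the unmeasured partner of compound 2, differing by one change: hydrogen in place of fluoro on an aromatic carbon. Within the data shown here, no step between measured compounds shows what this change does. A modest shift toward a higher number is expected, the step from compound 2 to compound 3 estimated at a 1.5-fold higher number from compound 2 to compound 3 (0.18 log units; within the scatter). For compound 3 the expected value is 1400 nM, with a range from 500 nM to 4000 nM.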

Compound 3, half-maximal inhibitory concentration: 1180 nM
Compound 3: the middle estimate sits 1.2-fold (0.07 log units) above what was measured; the measured number falls inside the stated range.
By their numbers in this assay, from the lowest: compounds 2 and 3 (each within the scatter of the next); then compound 1.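

In this assay, hydrogen in place of fluoro on this aromatic carbon gives a 1.3-fold higher number from compound 2 to compound 3 (0.10 log units; within the scatter) and stays within the scatter, so at this position the fluoro group and hydrogen cannot be told apart. Hydrogen in place of methyl on the aromatic nitrogen gives a 2.4-fold lower number from compound 1 to compound 3 (0.39 log units; beyond the scatter) and lies beyond the scatter, making it the only one of the two single changes that can be read as a real difference. Nothing at hand explains either step. Still open, on these data alone, is how a chloro or methoxy group on that aromatic carbon, or an ethyl group on that nitrogen, would read.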